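The source may report more compounds than this note shows. Statements on the series, on what has been measured and on what is new or still open speak of the compounds shown alone.

Series notes, THP-1 growth inhibition

Measured compounds:
compound 1 `COC(=O)[C@@]1(C)C[C@@H](c2coc3ccc(F)cc3c2=O)N(c2ccccc2)O1`: 47000 nM
compound 2 `O=c1c([C@@H]2C[C@H](c3ccccc3)ON2c2ccccc2)coc2cc(Cl)c(Cl)cc12`: 38000 nM
compound 3 `O=C1[C@H]2[C@H](ON(c3ccccc3)[C@@H]2c2coc3ccc(Br)cc3c2=O)C(=O)N1c1ccccc1`: 22300 nM

All three numbers come from a functional assay on THP-1 cells (Homo sapiens) for inhibition, read by sulforhodamine B assay, with a stated time of 48 h; a higher number here means a weaker inhibitor, a lower number a stronger inhibitor. Compound 2 has the second highest of the three numbers; compound 1 sits within the scatter of it, and so does compound 3, so no order among the three can be read from these values. Going by the values given here, the whole set lies in a weak range, and the three compounds differ from one another in more than one place, so no single-change step between measured compounds is available to lean on.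

Compound 4 `CCO[C@H]1C[C@@H](c2coc3cc(Cl)c(Cl)cc3c2=O)N(c2ccccc2)O1` is the next compound, not yet measured in this assay . It is derived from compound 2 by the change (ethoxy in place of phenyl on a saturated ring carbon). With no measured step of this kind in the series, there is no ground for expecting a move beyond the scatter in either direction; the expected step from compound 2 to compound 4 is a 1.1-fold higher number from compound 2 to compound 4 (0.02 log units; within the scatter). Compound 4 is therefore estimated at 40000 nM, with a range of 15000 nM to 110000 nM, the wide range reflecting the absence of any comparable step among the measured compounds.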

Compound 4, half-maximal inhibitory concentration: 16500 nM
Compound 4: middle estimate off by 2.4-fold (0.38 log units), on the high side, and the stated range covers the measured number.
By their numbers in this assay, from the lowest: compounds 4, 3, 2 and 1 (each within the scatter of the next, the first and the last beyond it).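

Going by these compounds alone, this is the first single-change step: on the saturated ring carbon next to the ring oxygen, ethoxy in place of phenyl gives a 2.3-fold lower number from compound 2 to compound 4 (0.36 log units; beyond the scatter) in this assay. The phenyl at this position is therefore not needed to keep the activity seen with compound 2, since a group with no ring gives a modest gain, though this rests on a single pair and the numbers remain weak. Nothing at hand accounts for the size or direction of this step.

Open, going by these compounds, is whether the gain belongs to ethoxy itself or follows from losing the phenyl, which a methoxy, a longer alkoxy chain, or an amine on the same carbon would help separate. Also open, on these data alone, is whether the step carries over to a core with a different halogen pattern, such as the fluoro or bromo cores of compound 1 and compound 3.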